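A Methyl-Thiadiazole Swap on a Sulfonamide Nitrogen

A few compounds are considered here, and "the series" means these few. Any claim that something is new, unique, unknown or untested is made for them only; others in the source may bear on it.

In a physicochemical assay for solubility, read by HPLC, measured as thermodynamic solubility, with a stated time of 4 h, at pH 6.8 (a lower number here means a less soluble compound, a higher number a more soluble compound), compound 2 `Cn1nccc1[C@H]1CCC[C@@H]1Oc1cc(F)c(S(=O)(=O)Nc2nccs2)cc1F` gives 250000 nM, the lower of the two actual numbers available. Compound 1 `Cn1nccc1[C@H]1CCCC[C@@H]1Oc1cc(F)c(S(=O)(=O)Nc2ccncn2)c(F)c1` stands higher at 1800000 nM, a gap beyond the scatter. Compound 3 `Cn1nccc1[C@H]1CCC[C@@H]1Oc1cc(F)c(S(=O)(=O)Nc2ncns2)cc1F` gives > 1900000 nM, which is a limit of the assay and not a number.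

The change to compound 4 `Cc1nsc(NS(=O)(=O)c2cc(F)c(O[C@H]3CCC[C@@H]3c3ccnn3C)cc2F)n1` is 3-methyl-1,2,4-thiadiazol-5-yl in place of 1,3-thiazol-2-yl on a sulfonamide nitrogen. For the measured compounds named here, one measured step bears on it, an at least 7.6-fold higher number from compound 2 to compound 3 (0.88 log units; beyond the scatter), which lies beyond the scatter and removes the same group from the same place. Its size is bounded by the limit of > 1900000 nM in this assay, at which 1 of the 3 values shown sits. The group entering in that step is 1,2,4-thiadiazol-5-yl, without the 3-methyl, so its carry-over is uncertain.

A rise in this assay is therefore expected, probably beyond the scatter but more modest than that step, with the estimate being a 2.8-fold higher number from compound 2 to compound 4 (0.45 log units; beyond the scatter). For compound 4 the estimated value is 700000 nM, with an expected range of 250000 nM to 2000000 nM.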

Compound 4, solubility: 1800000 nM
For compound 4 the middle estimate is 2.6-fold (0.41 log units) below the measured one, and the stated range covers the measured number.
By their numbers in this assay, from the lowest: compound 2; then compounds 1 and 4 (each within the scatter of the next). At a limit, above all of these: compound 3.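

In this assay, 3-methyl-1,2,4-thiadiazol-5-yl in place of 1,3-thiazol-2-yl on the sulfonamide nitrogen gives a 7.2-fold higher number from compound 2 to compound 4 (0.86 log units; beyond the scatter), beyond the scatter, so the rise seen with the unsubstituted 1,2,4-thiadiazol-5-yl group survives the added methyl. Methyl in place of hydrogen on an aromatic carbon gives an at least 1.0-fold lower number from compound 3 to compound 4 (0.02 log units; that floor lies within the scatter), and that floor lies within the scatter, so these compounds show no loss on adding the methyl, though they do not rule one out. Compound 3 carries a limit and not a number: the limit of > 1900000 nM in this assay, at which 1 of the 4 values shown sits.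

On these data alone, how large the methyl step really is remains open. Also open, as far as these compounds go, is how the number would respond to an amine, a methoxy group or a longer alkyl chain in place of the methyl on the 1,2,4-thiadiazol-5-yl group.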